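Swapping Benzylamino for Hexylsulfanyl on a Shared Core

The source may report more compounds than this note shows. Statements on the series, on what has been measured and on what is new or still open speak of the compounds shown alone.

Three measured compounds share one core and differ in a single group on it. Compound 1 `CNc1nc(N)nc2c1ncn2/C=C1/CC1(CO)CO` carries methylamino there, compound 2 `Nc1nc(OCc2ccccc2)c2ncn(/C=C3/CC3(CO)CO)c2n1` carries benzyloxy, and compound 3 `Nc1nc(NCc2ccccc2)c2ncn(/C=C3/CC3(CO)CO)c2n1` carries benzylamino. In an ADME assay on Akata cells (Homo sapiens) for cytotoxicity, with a stated time of 7 days (on this read-out higher numbers stand for lower toxicity in this test and lower numbers for higher toxicity in this test), compound 1 gives > 24000 nM, which is a limit of the test. In this assay compound 2 gives > 20000 nM, also a limit. In this assay compound 3 gives > 24000 nM, again a limit, so compound 3 stands among three limits with no measured number to set it against the others. The steps a step that the two limits leave unreadable from compound 1 to compound 2, a step that the two limits leave unreadable from compound 1 to compound 3 and a step that the two limits leave unreadable from compound 2 to compound 3 cannot be sized, since every value sits at the limit of > 20000 nM in this assay, at which 1 of the 3 values shown sits, or (the limit of > 24000 nM in this assay, at which 2 of the 3 values shown sit).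

Compound 4 `CCCCCCSc1nc(N)nc2c1ncn2/C=C1/CC1(CO)CO` differs from compound 3 by hexylsulfanyl in place of benzylamino on an aromatic carbon. Going by the values given here, no measured step touches hexylsulfanyl, so the three steps bear on it only in showing that methylamino, benzyloxy and benzylamino at this position all leave the toxicity beyond the reach of the test. In this assay compound 4 is therefore expected to give 24000 nM, within an estimated range from 8000 nM to 60000 nM, most likely reported as a limit once more. The expected step of a number no higher from compound 3 to compound 4 (the limit leaves the size open) is estimated to be none beyond the scatter.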

Compound 4, half-maximal cytotoxic concentration: > 20000 nM
Compound 4 was reported as a limit; the forecaster's own chance of this, stated with the estimate: 75%; the middle value does not contradict the limit.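

In this assay compound 4 gives > 20000 nM, which is a limit. Going by these compounds alone, the values of compound 1, compound 2 and compound 3 are limits too, so no step from any of them to compound 4 can be read. The compounds shown leave open how toxic any of the four actually is, and whether methylamino, benzyloxy, benzylamino and hexylsulfanyl differ at all in this read-out.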